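Swapping Chloro for Fluoro on Two Related Cores

A few compounds are considered here, and "the series" means these few. Any claim that something is new, unique, unknown or untested is made for them only; others in the source may bear on it.

Measured compounds:
compound 1 `O=C1C=C(Nc2cccc(F)c2)C(=O)c2c1nc1n2[C@H]2OC[C@@H](O)[C@H]2OC1`: 6440 nM
compound 2 `O=C1C=C(Nc2cccc(Cl)c2)C(=O)c2c1nc1n2[C@H]2OC[C@@H](O)[C@H]2OC1`: 6040 nM
compound 3 `O=C1C(Nc2cccc(Cl)c2)=CC(=O)c2c1nc1n2[C@H]2OC[C@@H](O)[C@H]2OC1`: 7970 nM

All three compounds were tested in a functional assay on HeLa cells (Homo sapiens) for inhibition, read by sulforhodamine B assay; on this read-out higher numbers stand for weaker inhibition and lower numbers for stronger inhibition. Compound 1 and compound 2 share one core; in this assay compound 2 gives 6040 nM and compound 1 gives 6440 nM. The change between them, (fluoro in place of chloro on an aromatic carbon), made a step of a 1.1-fold higher number from compound 2 to compound 1 (0.03 log units; within the scatter). Compound 3 has the same atoms as compound 2 joined differently, and in this assay compound 3 gives 7970 nM. The difference between the two cores is not broken down here; the numbers of compound 3 and compound 1 lie within the scatter of each other, as do those of compound 3 and compound 2.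

Compound 4 `O=C1C(Nc2cccc(F)c2)=CC(=O)c2c1nc1n2[C@H]2OC[C@@H](O)[C@H]2OC1` has not yet been measured. It differs from compound 3 by fluoro in place of chloro on an aromatic carbon, the same change as between compound 2 and compound 1, at the same kind of place. For compound 4 the expected value in this assay is 8500 nM, with a likely range from 4500 nM to 16000 nM. This estimate means an expected step of a 1.1-fold higher number from compound 3 to compound 4 (0.03 log units; within the scatter), because the same change on the other core gave a 1.1-fold higher number from compound 2 to compound 1 (0.03 log units; within the scatter).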

Compound 4, half-maximal inhibitory concentration: > 8000 nM
Compound 4 ended at the assay's limit (the forecaster's own chance of this, stated with the estimate: 5%); the middle value does not contradict the limit.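

In this assay compound 4 gives > 8000 nM, which is a limit of the assay and not a number. The step for fluoro in place of chloro on this core reads as a number no lower from compound 3 to compound 4 (the limit leaves the size open), so the swap did not lower the number here, but how far it raised it, if at all, cannot be told. This result fits the small step on the other core without confirming that the change carries across, since compound 4 could sit close to compound 3 or far from it: the same change on two cores in this assay, a 1.1-fold higher number (0.03 log units; within the scatter) from compound 2 to compound 1 and a number no lower (the limit leaves the size open) from compound 3 to compound 4; the limit leaves it open whether they differ

The compounds shown hold only chloro or fluoro on the aromatic ring, always in the same kind of place, so it remains open how either core would respond to a methoxy group, a nitrile or an amine there. On these data alone, it also remains open whether a larger replacement, such as trifluoromethyl, would give steps big enough to compare between the two cores.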